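The source may hold more compounds than are shown below. What is called first, only, known or untested is meant among the compounds shown, and "the series" means these compounds.

Of the compounds shown here, two have numbers so far in a functional assay on A549 cells (Homo sapiens) for cytotoxicity, read by sulforhodamine B assay, with a stated time of 72 h (a higher number here means a weaker inhibitor, a lower number a stronger inhibitor), on these cells. Compound 1 (`Nc1sc(-c2ccc(Br)cc2)c(-c2ccc(Cl)cc2)c1C(=O)NCc1ccccc1`) gives 18700 nM in this test, and compound 2 (`Clc1ccc(-c2sc3ncnc(NC4CC4)c3c2-c2ccc(Cl)cc2)cc1`) gives 42800 nM in the same test. Compound 2 therefore holds the higher of the two numbers and is the weaker inhibitor of the pair, with a gap beyond the usual scatter.

Compound 3 (`Clc1ccc(-c2sc3ncnc(N4CCCCC4)c3c2-c2ccc(Cl)cc2)cc1`) has not yet been measured. It keeps the core of compound 2 and differs at one place, with piperidin-1-yl in place of cyclopropylamino on an aromatic carbon of the six-membered aromatic ring with 2 nitrogen.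

Within the data shown here, no measured pair shows a change at this place, so the expectation rests on the value of compound 2 alone and stays loose. The expected step of a 1.4-fold lower number from compound 2 to compound 3 (0.15 log units; within the scatter) is estimated to stay within the scatter, with no clear direction. For compound 3 the estimated value in this assay is 30000 nM with an expected range from 11000 nM to 80000 nM as a working figure.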

Compound 3, half-maximal inhibitory concentration: > 50000 nM
Compound 3 was reported as a limit; the forecaster's own chance of this, stated with the estimate: 15%; at least 1.6-fold (0.22 log units) between middle value and limit.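

In this assay compound 3 gives > 50000 nM, which is a limit of the assay and not a number. At this position on the shared core, the change from cyclopropylamino to piperidin-1-yl gives an at least 1.1-fold higher number from compound 2 to compound 3 (0.06 log units; that floor lies within the scatter), so this first reading of the position shows no gain in strength from the swap, while neither the presence nor the size of any weakening can be established. The step can be read only as a floor because the result of compound 3 stands at the limit: the limit of > 50000 nM in this assay, at which 1 of the 3 values shown sits.

Two things change together in this swap, the ring, from three-membered to six-membered, and the hydrogen-bond donor, 1 in cyclopropylamino and 0 in piperidin-1-yl, so the compounds shown cannot separate ring size from the amino hydrogen. An open-chain butylamino group, a dimethylamino group or a morpholin-4-yl group at the same carbon would help to tell these apart, and a plain amino group would show how the position reads with no ring or chain attached to the nitrogen.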